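The source may hold more compounds than are shown below. What is called first, only, known or untested is meant among the compounds shown, and "the series" means these compounds.

Measured compounds:
compound 1, `COc1ccc2[nH]c(C(=O)N3CC(=O)N(Cc4ccccc4)[C@@H](CN4CCCCC4)C3)cc2c1`: 76900 nM
compound 2, `O=C(c1cc2cc(C3CC3)ccc2[nH]1)N1CC(=O)N(Cc2ccccc2)[C@@H](CN2CCC(F)CC2)C1`: 24500 nM

In an ADME assay on Vero cells (Chlorocebus sabaeus) for cytotoxicity, with a stated time of 7 days (on this read-out lower numbers stand for higher toxicity in this test and higher numbers for lower toxicity in this test), compound 1 gives 76900 nM, which is the highest of the two numbers at hand. Compound 2 gives 24500 nM in this assay, a lower number than that of compound 1, and the gap between the two lies beyond the usual scatter. Compound 3, `COc1ccc2[nH]c(C(=O)N3CC(=O)N(Cc4ccccc4)[C@@H](CN4CCc5ccccc5C4)C3)cc2c1`, has not yet been measured in this assay. It differs from compound 1 by 1,2,3,4-tetrahydroisoquinolin-2-yl in place of piperidin-1-yl on a saturated chain carbon bound to a saturated ring carbon; the shared core of compound 1 is otherwise kept. Among the measured compounds shown here, no measured pair in this set shows the same change, so nothing here indicates how large its effect should be. The account therefore expects only a modest step in this assay, toward a lower number, of a 1.9-fold lower number from compound 1 to compound 3 (0.28 log units; within the scatter), and this step may not exceed the scatter. On that basis compound 3 is estimated at 40000 nM, within a range from 15000 nM to 100000 nM.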

Compound 3, half-maximal cytotoxic concentration: 51800 nM
Compound 3: the middle estimate sits 1.3-fold (0.11 log units) below what was measured; the measured number falls inside the stated range.
By their numbers in this assay, from the lowest: compound 2; then compounds 3 and 1 (each within the scatter of the next).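

In this assay, among the compounds shown here, the exchange of piperidin-1-yl for 1,2,3,4-tetrahydroisoquinolin-2-yl on a saturated chain carbon bound to a saturated ring carbon gives a 1.5-fold lower number from compound 1 to compound 3 (0.17 log units; within the scatter) and is the first change in a single place that can be read in this set. At this place, then, a six-membered aromatic ring of carbon only was added to the amine while the shared core was kept, and the read-out did not move beyond the scatter. No measurement at hand bears on why this result came out as it did.

The compounds shown leave open whether morpholin-4-yl or an open-chain amine such as dimethylamino would also stay within the scatter of compound 1 at this place. They also leave open whether a carboxylic acid on the same chain would do so.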